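A few compounds are considered here, and "the series" means these few. Any claim that something is new, unique, unknown or untested is made for them only; others in the source may bear on it.

Of the compounds shown here, three have so far been tested in an in vitro assay on HEK385-7 cells for displacement of a labelled ligand from prostaglandin D2 receptor 2 (Homo sapiens); a higher number here means a weaker inhibitor, a lower number a stronger inhibitor. Compound 1 `O=C(O)Cc1sc(COc2ccc(Cl)cc2)nc1-c1ccc(Cl)cc1` gives 32 nM, and compound 2 `O=C(O)Cc1sc(C(c2ccccc2)c2ccc(F)cc2)nc1-c1ccc(Cl)cc1` gives 17 nM. Compound 3 `O=C(O)Cc1sc(C(c2ccc(F)cc2)c2ccc(F)cc2)nc1-c1cccc(F)c1` gives 1.4 nM, the lowest of the three numbers, with compound 2 nearest to it and compound 1 furthest away, both gaps lying beyond the scatter.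

Compound 4 `O=C(O)Cc1sc(C(c2ccc(F)cc2)c2ccc(F)cc2)nc1-c1cn[nH]c1` has not yet been measured in this assay. It differs from compound 3 in one place: 1H-pyrazol-4-yl in place of 3-fluorophenyl on an aromatic carbon. Among the compounds with values here, no measured pair shows this kind of exchange, so the step is a guess from the structures alone. A moderate loss is expected; compound 4 is expected to give 10 nM, with a range from 2 nM to 50 nM, a step of a 7.1-fold higher number from compound 3 to compound 4 (0.85 log units; beyond the scatter) that is expected to reach beyond the scatter.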

Compound 4, half-maximal inhibitory concentration: 16 nM
Compound 4: middle estimate off by 1.6-fold (0.20 log units), on the low side; the range from low to high includes it.
By their numbers in this assay, from the lowest: compound 3; then compounds 4, 2 and 1 (each within the scatter of the next).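

Exchanging 3-fluorophenyl for 1H-pyrazol-4-yl on the aromatic carbon next to the ring nitrogen gives an 11-fold higher number from compound 3 to compound 4 (1.06 log units; beyond the scatter), the first step read at this position, and a large one. The position is therefore sensitive to this change, yet compound 4 still gives 16 nM, so binding is not abolished. Nothing available explains the size of this loss. Going by these compounds, what remains open is whether the loss follows the smaller ring or its nitrogen atoms. An unsubstituted phenyl, a pyridin-3-yl or a 1-methyl-1H-pyrazol-4-yl group at this position would help separate these.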